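Swapping Morpholine for Pyrrolidine: Expected Cell Toxicity

This account rests on a few compounds, and the source may have more. Where it says the series, first, only, none or still open, it means among the compounds named here.

Compound 2 `Cc1cc(C)c(Oc2cc(Nc3ccc(C#N)cc3)ncc2C(=O)NCc2cn(CC(=O)N3CCOCC3)nn2)c(C)c1` is one of two compounds tested in an ADME assay on MT4 cells (Homo sapiens) for cytotoxicity, read by MTT assay, with a stated time of 5 days; on this read-out higher numbers stand for lower toxicity in this test and lower numbers for higher toxicity in this test; in that test compound 2 gives 181000 nM, the higher of the two numbers shown. Compound 1 `CCOC(=O)Cn1cc(CNC(=O)c2cnc(Nc3ccc(C#N)cc3)cc2Oc2c(C)cc(C)cc2C)nn1` gives 9530 nM in this assay. Going by the values given here, the only measured step is a 19-fold higher number from compound 1 to compound 2 (1.28 log units; beyond the scatter), a change of a different kind from the one considered here. Compound 3 `Cc1cc(C)c(Oc2cc(Nc3ccc(C#N)cc3)ncc2C(=O)NCc2cn(CC(=O)N3CCCC3)nn2)c(C)c1` differs from compound 2 by pyrrolidin-1-yl in place of morpholin-4-yl on a carbonyl carbon. No measured step exchanges one ring amide for another, so the step from compound 1 to compound 2 offers only indirect guidance, and nothing shown argues for a shift of that size. Compound 3 is therefore expected to show a step of a 1.6-fold lower number from compound 2 to compound 3 (0.22 log units; within the scatter), within or near the scatter. The estimate for compound 3 in this assay is 110000 nM, in a range from 35000 nM to 280000 nM.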

Compound 3, half-maximal cytotoxic concentration: 58100 nM
The estimate for compound 3 lay 1.9-fold (0.28 log units) above the measured number; measured number inside the range.
By their numbers in this assay, from the lowest: compound 1; then compound 3; then compound 2.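

Exchanging one ring amide for another on this carbonyl carbon is not a neutral change in this assay: the swap of morpholin-4-yl for pyrrolidin-1-yl gives a 3.1-fold lower number from compound 2 to compound 3 (0.49 log units; beyond the scatter), a step that the earlier pair could not reveal. Pyrrolidin-1-yl in place of ethoxy still gives a 6.1-fold higher number from compound 1 to compound 3 (0.79 log units; beyond the scatter), so a ring amide at this place need not match morpholin-4-yl to stand clearly higher than the ethoxy compound, and compound 3 lands between the other two. No measurement shown here explains why the two rings differ.
The ring oxygen and the ring size change together in this step, so the compounds shown cannot separate them. Piperidin-1-yl, a six-membered ring without oxygen, would pull these two changes apart, and it remains open where it would fall.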